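The source may report more compounds than this note shows. Statements on the series, on what has been measured and on what is new or still open speak of the compounds shown alone.

Three compounds share one core, seen in compound 1 `COc1ccc(NC(=O)c2csc(Cc3c(Cl)cccc3Cl)n2)cc1`, compound 2 `O=C(Nc1ccc(Br)cc1)c1csc(Cc2c(Cl)cccc2Cl)n1` and compound 3 `O=C(Nc1ccc(Br)cn1)c1csc(Cc2c(Cl)cccc2Cl)n1`; they differ only in the group on the amide-type nitrogen. In an assay on CHO cells, read by calcium flux (on this read-out lower numbers stand for stronger inhibition and higher numbers for weaker inhibition), compound 2 gives 460 nM. For compound 1 the read-out is a limit, > 4000 nM. For compound 3 the read-out is likewise a limit, > 4000 nM. Compound 3 therefore stands at the limit of > 4000 nM in this assay, at which 2 of the 3 values shown sit, with no number of its own. Bromo in place of methoxy reads an at least 8.6-fold lower number from compound 1 to compound 2 (0.93 log units; beyond the scatter); the move to the pyridinyl reads an at least 8.6-fold higher number from compound 2 to compound 3 (0.93 log units; beyond the scatter); the gap a step that the two limits leave unreadable from compound 1 to compound 3 cannot be read from two limits.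

Compound 4 `O=C(Nc1ccccc1Br)c1csc(Cc2c(Cl)cccc2Cl)n1` carries 2-bromophenyl in place of 5-bromopyridin-2-yl on an amide-type nitrogen. Within the data shown here, the step that bears on it is an at least 8.6-fold higher number from compound 2 to compound 3 (0.93 log units; beyond the scatter), taken in the reverse sense, since a 2-bromophenyl again replaces the 5-bromopyridin-2-yl; the bromine, however, now sits in a 2-bromophenyl rather than the 4-bromophenyl of compound 2, and no measured pair shows what that shift does. A lower number than the limit of compound 3 is expected in this assay, with compound 4 estimated at 1500 nM (range 300 nM to 6000 nM), which is expected to mean an at least 2.6-fold lower number from compound 3 to compound 4 (0.42 log units; beyond the scatter), while a second limit remains possible.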

Compound 4, half-maximal inhibitory concentration: > 4000 nM
Compound 4: no number, only a limit; the forecaster's own chance of this, stated with the estimate: 30%; middle value at least 2.6-fold (0.42 log units) away from the limit.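

Moving the bromine on the phenyl group, with 2-bromophenyl in place of 4-bromophenyl on the amide-type nitrogen, gives an at least 8.6-fold higher number from compound 2 to compound 4 (0.93 log units; beyond the scatter) in this assay. A bromine on the phenyl group is therefore not enough by itself to give a number of the kind seen for compound 2, which now stands alone among the compounds shown, while the 4-methoxyphenyl, 5-bromopyridin-2-yl and 2-bromophenyl groups all end in a limit: the limit of > 4000 nM in this assay, at which 3 of the 4 values shown sit. The steps joining compound 4 with compound 1 and with compound 3 cannot be read, as each pair consists of two limits, so these three compounds cannot be placed in any order.

From the compounds shown here alone, how far each of these three compounds lies past its limit remains open, and so does any ranking among the 4-methoxyphenyl, 5-bromopyridin-2-yl and 2-bromophenyl groups. Also open, going by these compounds, is whether an unsubstituted phenyl, a chlorophenyl or a phenyl carrying a carboxylic acid on the amide-type nitrogen would give a number of its own in this assay, and how such a number would compare with that of compound 2.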